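This account rests on a few compounds, and the source may have more. Where it says the series, first, only, none or still open, it means among the compounds named here.

Working notes on the series.

Within the data shown here, compound 1 `Oc1ccc(-c2cc(-c3ccccc3F)cc(-c3cccc(O)c3)n2)cc1` stands at the weaker end of the two numbers known so far: in a functional assay on T47D cells (Homo sapiens) for inhibition (on this read-out lower numbers stand for stronger inhibition and higher numbers for weaker inhibition), compound 1 gives 6370 nM. Among the measured compounds shown here, compound 2 `Oc1ccc(-c2cc(-c3cccc(F)c3)cc(-c3cccc(O)c3)n2)cc1` is its only measured neighbour and in this assay compound 2 gives 3510 nM; the step of a 1.8-fold lower number from compound 1 to compound 2 (0.26 log units; within the scatter) stays within the scatter, so the two numbers cannot be ordered.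

Compound 3 `Oc1ccc(-c2cc(-c3ccccc3OC(F)(F)F)cc(-c3cccc(O)c3)n2)cc1` differs from compound 1 by trifluoromethoxy in place of fluoro on an aromatic carbon. For the measured compounds named here, no measured step changes the fluoro into another group; the single step on record, from compound 1 to compound 2, only moves the fluoro along the ring and remains within the scatter. It bears on the present change only loosely, and nothing in the data indicates that the trifluoromethoxy group should shift the number beyond the scatter in either direction.

For compound 3 the expected step of a 1.1-fold lower number from compound 1 to compound 3 (0.03 log units; within the scatter) is therefore set near zero, with a broad range reflecting the absence of a direct precedent. Compound 3 is estimated at 6000 nM in this assay, between 2000 nM and 20000 nM.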

Compound 3, half-maximal inhibitory concentration: 7300 nM
The estimate for compound 3 lay 1.2-fold (0.09 log units) below the measured number; measured number inside the range.
By their numbers in this assay, from the lowest: compounds 2, 1 and 3 (each within the scatter of the next, the first and the last beyond it).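

Among these compounds, the step of a 1.1-fold higher number from compound 1 to compound 3 (0.06 log units; within the scatter) in this assay gives the first reading of a change of the group itself at this place, on an aromatic carbon ortho to a large group, since the earlier step only moved the fluoro along the ring. Trifluoromethoxy, with 5 heavy atoms and 1 hydrogen-bond acceptor, replaces fluoro, with 1 heavy atom and 0 hydrogen-bond acceptors, and the number of compound 3 cannot be told apart from that of compound 1. No accompanying measurement bears on this result, so the reading goes no further than the numbers themselves.

The compounds shown leave open whether any substituent at this place can move the number beyond the scatter, for instance an amine or a carboxylic acid, which would differ from both fluoro and trifluoromethoxy in kind and not only in size. They also leave open whether trifluoromethoxy at the place the fluoro holds in compound 2 would give a number close to that of compound 2, and so whether the position matters at all for this group.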